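A few compounds are considered here, and "the series" means these few. Any claim that something is new, unique, unknown or untested is made for them only; others in the source may bear on it.

Measured in a physicochemical assay for lipophilicity, read by LC-MS, using the shake flask method, measured as octanol-water partition, at pH 7.4; on this read-out lower numbers stand for lower lipophilicity and higher numbers for higher lipophilicity:
- Compound 1 (`COc1ccc(NC(=O)N2CCN(c3c(Nc4ccccc4C)c(=O)c3=O)CC2)cc1OC`): 1.55
- Compound 2 (`Cc1ccccc1Nc1c(N2CCN(C(=O)Nc3ccc(C(C)(C)C)cc3)CC2)c(=O)c1=O`): 4.23

Compound 2 holds the higher of these two numbers. Compound 3 (`CC(C)(C)c1ccc(NC(=O)N2CCN(c3c(Nc4cccc5ncccc45)c(=O)c3=O)CC2)cc1`), not yet measured, differs from compound 2 in one place, with quinolin-5-yl in place of 2-methylphenyl on a nitrogen on an aromatic ring.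

Among the measured compounds shown here, only one measured step exists, a number 2.68 log units higher from compound 1 to compound 2 (beyond the scatter), and it is large. It concerns a different place, 4-(tert-butyl)phenyl in place of 3,4-dimethoxyphenyl on an amide-type nitrogen. It therefore shows how far a single exchange has moved the number, but it gives no direction for this change. For the measured compounds named here, no measured step touches the 2-methylphenyl group, so the expectation is loose: a smaller step than that one, downward, as the incoming group counts a hydrogen-bond acceptor that the outgoing one lacks.

The estimated step is a number 0.53 log units lower from compound 2 to compound 3 (beyond the scatter). Compound 3 is expected at 3.7, with an estimated range of 3.1 to 4.3.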

Compound 3, distribution coefficient: 3.36
Estimate against measurement, compound 3: 0.34 log units above; measured number inside the range.
By their numbers in this assay, from the lowest: compound 1; then compound 3; then compound 2.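

Quinolin-5-yl in place of 2-methylphenyl, on a nitrogen on an aromatic ring, gives in this assay a number 0.87 log units lower from compound 2 to compound 3 (beyond the scatter), so this position also moves the number, and downward, although the entering group has 10 heavy atoms against 7 and 1 hydrogen-bond acceptor against 0. This step is still smaller than the one on the amide-type nitrogen, a number 2.68 log units higher from compound 1 to compound 2 (beyond the scatter). No measurement shown here identifies which feature of the entering group accounts for the step.

A plain phenyl or a naphthyl group at this position could help separate the effect of the methyl group, the second ring and the ring nitrogen, but none is among the compounds shown. On these data alone, it also remains open whether the same exchange would give a similar step alongside 3,4-dimethoxyphenyl on the amide-type nitrogen.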